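The source may hold more compounds than are shown below. What is called first, only, known or untested is meant among the compounds shown, and "the series" means these compounds.

In a functional assay on CHO cells for agonist activity at Alpha-1A adrenergic receptor (Homo sapiens), read by FLIPR and calcium flux (a higher number here means that more compound is needed for the effect, a lower number that less compound is needed), three compounds built on a shared core have been measured. Compound 1 `COc1c(C)ccc2c1CCC2c1ncc[nH]1` gives 167 nM. Compound 2 `Cn1nccc1-c1cccc2c1CCC2c1ncc[nH]1` gives 278 nM. Compound 3 `Clc1ccc2c(c1-c1ccn[nH]1)CCC2c1ncc[nH]1` gives 322 nM. Compound 2 thus stands with a number that lies within the usual scatter of both of its neighbours: the gap to compound 3 is the narrower one and the gap to compound 1 the wider one, yet neither gap exceeds what repeated measurements of this kind produce on their own, so none of the three can be set above or below another on these data.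

Compound 4 `c1cc(-c2nccs2)c2c(c1)C(c1ncc[nH]1)CC2` has not yet been measured in this assay. It differs from compound 2 in one place: 1,3-thiazol-2-yl in place of 1-methyl-1H-pyrazol-5-yl on an aromatic carbon. Among the compounds with values here, no pair of measured compounds differs in a single place, so there is no measured step to lean on; what is in hand are three close numbers, and both the group that leaves and the group that enters are five-membered aromatic rings with two hetero atoms. The step from compound 2 to compound 4 is expected to be a 1.1-fold lower number from compound 2 to compound 4 (0.05 log units; within the scatter), nothing beyond the scatter in either direction. Compound 4 is therefore estimated at 250 nM, with a range from 90 nM to 700 nM.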

Compound 4, half-maximal effective concentration: 426 nM
Estimate against measurement, compound 4: 1.7-fold (0.23 log units) below, within the range that was stated.
By their numbers in this assay, from the lowest: compounds 1, 2, 3 and 4 (each within the scatter of the next, the first and the last beyond it).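

In this assay, within the data shown here, this pair gives the first step in which only one place changes: on an aromatic carbon of a six-membered aromatic ring of carbon only, 1,3-thiazol-2-yl takes the place of 1-methyl-1H-pyrazol-5-yl, giving a 1.5-fold higher number from compound 2 to compound 4 (0.19 log units; within the scatter). The earlier compounds shown here offered no such single-place comparison, whereas this pair shows that, for this one exchange, a sulfur-containing five-membered aromatic ring and a methylated one with two nitrogens cannot be told apart at this position, even though the two groups differ in their heavy atoms. Nothing at hand offers an explanation for the size of this step, and the data support no cause for it.

This single exchange links two five-membered aromatic rings with two hetero atoms, so it says nothing about how a phenyl or 2-pyridyl ring, a primary amine, a carboxylic acid or a longer chain such as n-butyl would fare at the same place. Going by these compounds, whether the step would stay within the scatter on a core carrying a further substituent, such as the chlorine of compound 3, also remains open.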